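Benzyloxy analogue of compound 2: expected potency

The compounds below may be only part of what the source reports. "The series", "measured", "known", "first", "only" and "open" are said of these compounds alone.

Values in an assay on cells for antagonist activity at transient receptor potential cation channel subfamily V member 1 (Homo sapiens), read by FLIPR and calcium flux, with a stated time of 6 min; a lower number here means a stronger inhibitor, a higher number a weaker inhibitor:
compound 1 `CCCN(CCC)c1nc(C(C)(C)C)ccc1CNC(=O)C(C)c1ccc(NS(C)(=O)=O)c(F)c1`: 2.5 nM
compound 2 `CCCCOc1nc(C(C)(C)C)ccc1CNC(=O)C(C)c1ccc(NS(C)(=O)=O)c(F)c1`: 0.9 nM
compound 3 `CCOCCOc1nc(C(C)(C)C)ccc1CNC(=O)C(C)c1ccc(NS(C)(=O)=O)c(F)c1`: 23.9 nM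

Compound 2 holds the lowest of the three numbers: a 2.8-fold lower number from compound 1 to compound 2 (0.44 log units; beyond the scatter), and a 27-fold higher number from compound 2 to compound 3 (1.42 log units; beyond the scatter). Compound 4 `CC(C(=O)NCc1ccc(C(C)(C)C)nc1OCc1ccccc1)c1ccc(NS(C)(=O)=O)c(F)c1` differs from compound 2 by phenyl in place of propyl on a saturated chain carbon bound to an oxygen on an aromatic ring. Of the measured steps only a 27-fold higher number from compound 2 to compound 3 (1.42 log units; beyond the scatter) touches the same saturated chain; that step, which brought in an acceptor, was large. The present change brings in a six-membered aromatic ring of carbon only and no donor or acceptor, so a step of that size is not expected in this assay, though some loss beyond the scatter seems plausible. Compound 4 is therefore estimated at 2 nM, with a range of 0.5 nM to 8 nM, meaning an expected 2.2-fold higher number from compound 2 to compound 4 (0.35 log units; beyond the scatter).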

Compound 4, inhibition constant: 4.4 nM
Estimate against measurement, compound 4: 2.2-fold (0.34 log units) below; measured number inside the range.
By their numbers in this assay, from the lowest: compound 2; then compounds 1 and 4 (each within the scatter of the next); then compound 3.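

In this assay, phenyl on the saturated chain carbon bound to an oxygen on an aromatic ring costs only a modest step against propyl (a 4.9-fold higher number from compound 2 to compound 4 (0.69 log units; beyond the scatter)), so a six-membered aromatic ring of carbon only is tolerated at this place. At the same place, phenyl fares better than ethoxymethyl (a 5.4-fold lower number from compound 3 to compound 4 (0.73 log units; beyond the scatter)), while benzyloxy and dipropylamino on the aromatic carbon are not separated (a 1.8-fold higher number from compound 1 to compound 4 (0.25 log units; within the scatter)). No evidence accompanying these values explains the differences. Open, as far as these compounds go, is how a pyridine ring or a chlorophenyl group would compare with phenyl at this place.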